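Fluorocyclopropyl Amide on a Bicyclic Diamine Core

The source may report more compounds than this note shows. Statements on the series, on what has been measured and on what is new or still open speak of the compounds shown alone.

Within the data shown here, compound 1 `CC(=O)N1CC2CC(C1)N2` gives 95% in an assay on SH-EP1 cells for agonist activity at Neuronal acetylcholine receptor; alpha4/beta2 (Homo sapiens), read by FLIPR and calcium flux (on this read-out higher numbers stand for larger maximal responses and lower numbers for smaller maximal responses), and stands highest of the two numbers known so far; compound 2 `CC(C)C(=O)N1CC2CC(C1)N2` gives 71%. Among the measured compounds shown here, the only measured step, a number 24 percentage points lower from compound 1 to compound 2 (beyond the scatter), bears on the present question, as it also enlarges the group on the carbonyl carbon. Compound 3 `O=C([C@@H]1C[C@@H]1F)N1CC2CC(C1)N2` differs from compound 1 by 2-fluorocyclopropyl in place of methyl on a carbonyl carbon. A downward step of modest size, comparable to the one known, is expected: a number 20 percentage points lower from compound 1 to compound 3 (beyond the scatter). Compound 3 is accordingly estimated at 75%, with a range from 55% to 95%.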

Compound 3, largest response reached (Emax), in percent of the reference or control that the assay uses: 110%
Compound 3: the middle estimate sits 35 percentage points below what was measured; the measured number lies above the stated range.
By their numbers in this assay, from the lowest: compound 2; then compound 1; then compound 3.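

In this assay, a larger group on the carbonyl carbon need not lower the response: 2-fluorocyclopropyl in place of methyl gives a number 15 percentage points higher from compound 1 to compound 3 (beyond the scatter) and so reverses the direction seen with isopropyl. In place of isopropyl, the same group gives a number 39 percentage points higher from compound 2 to compound 3 (beyond the scatter) and so separates two groups that both enlarge this position. Nothing at hand accounts for this reversal.

The compounds shown leave open how a plain cyclopropyl or a fluoromethyl group would read on this carbonyl carbon. They also leave open whether the opposite configuration at the two stereocentres would give the same response.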